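The source may hold more compounds than are shown below. What is called first, only, known or untested is meant among the compounds shown, and "the series" means these compounds.

Among the compounds with values here, in a functional assay on the whole organism (heart) with Rattus norvegicus as the target (on this read-out lower numbers stand for an effect already at smaller amounts and higher numbers for an effect only at larger amounts of compound), compound 3 `CC(=O)/C(=C\c1ccccc1)Oc1ccc(OCC(C)N(C)C)cc1` gives 3 mg/kg and lies within the scatter of compound 1 `CC(=O)/C(=C\c1ccccc1)Oc1ccccc1OCCCN1CCN(C)CC1` at 2.5 mg/kg while compound 2 `CC(=O)/C(=C\c1ccccc1)Oc1ccccc1OCC(C)N(C)C` shows a smaller number at 0.9 mg/kg for the series so far. Compound 4 `CC(=O)/C(=C\c1ccccc1)Oc1ccc(OCC(O)NC(C)(C)C)cc1` differs from compound 3 by hydroxy((tert-butyl)amino)methyl in place of 1-(dimethylamino)ethyl on a saturated chain carbon bound to an oxygen on an aromatic ring on a saturated chain carbon bound to an oxygen on an aromatic ring. Within the data shown here, the only measured step that changes this amine-bearing group is modest (a 2.8-fold lower number from compound 1 to compound 2 (0.44 log units; beyond the scatter)) and does not involve hydroxy((tert-butyl)amino)methyl. It gives no firm direction here, so no step beyond the scatter is expected. The estimated step is a 1.5-fold lower number from compound 3 to compound 4 (0.18 log units; within the scatter) in this assay for now. For compound 4 the expected value is 2 mg/kg (estimated range 0.5 mg/kg to 6 mg/kg).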

Compound 4, dose for half-maximal effect: 3.5 mg/kg
Beside the measured number, compound 4's estimate is 1.8-fold (0.24 log units) below it; the range from low to high includes it.
By their numbers in this assay, from the lowest: compound 2; then compounds 1, 3 and 4 (each within the scatter of the next).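

In this assay, hydroxy((tert-butyl)amino)methyl in place of 1-(dimethylamino)ethyl on a saturated chain carbon bound to an oxygen on an aromatic ring gives a 1.2-fold higher number from compound 3 to compound 4 (0.07 log units; within the scatter). This position therefore tolerates a hydroxy group and a tert-butyl group on the amine-bearing chain without a step beyond the scatter in this pair. Nothing available bears on the reason for this result. As far as these compounds go, it remains open whether the same change on compound 2 would also stay within the scatter. From the compounds shown here alone, it is also open how a carboxylic acid or a longer chain carrying the amine would read at this position.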